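The source may report more compounds than this note shows. Statements on the series, on what has been measured and on what is new or still open speak of the compounds shown alone.

Compound 1 `COc1cccc([C@@H](C)NC(=O)c2ccc(-c3cn[nH]c3)c(C)c2)c1`: in an assay on isolated protein for inhibition of Rho-associated protein kinase 1 (Homo sapiens), read by mobility shift assay (a higher number here means a weaker inhibitor, a lower number a stronger inhibitor), compound 1 gives 8.7 nM.
Compound 2 `COc1cc(NC(=O)[C@H](N)CCc2ccccc2)ccc1-c1cn[nH]c1`: in this assay compound 2 gives 7.2 nM.

Compound 2 holds the lowest of the two numbers, but its nearest neighbour, compound 1, sits only slightly higher and within the scatter, so neither can be called the stronger inhibitor on these numbers. Compound 3 `COc1cc(NC(=O)[C@@H](N)CCc2ccccc2)ccc1-c1cn[nH]c1` is the next step from compound 2: the two compounds have the same atoms and bonds and differ only in configuration as drawn: 1 of 1 stereo elements differ; a stereocentre at a saturated chain carbon is drawn R in compound 2 and S in compound 3. Going by the values given here, the two structures are mirror images at that single centre, and no measured pair here shows what such a flip does in this assay. A change of configuration alone often separates two otherwise identical molecules widely, and the expectation is a clear step towards weaker inhibition, an 11-fold higher number from compound 2 to compound 3 (1.05 log units; beyond the scatter), beyond the scatter. Compound 3 is therefore estimated at 80 nM in this assay, with a plausible range from 10 nM to 600 nM.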

Compound 3, half-maximal inhibitory concentration: 48 nM
Beside the measured number, compound 3's estimate is 1.7-fold (0.22 log units) above it; low and high end bracket the measured number.
By their numbers in this assay, from the lowest: compounds 2 and 1 (each within the scatter of the next); then compound 3.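

Going by these compounds alone, this is the first measured pair in which a single stereocentre at a saturated chain carbon is the only thing that changes, and in this assay drawing it S rather than R gives a 6.7-fold higher number from compound 2 to compound 3 (0.82 log units; beyond the scatter). The step can be laid on the configuration alone, because nothing else separates the two molecules: the fact that compounds 2 and 3 differ only in the configuration as drawn. The flip weakens inhibition without removing it, since compound 3 still gives 48 nM, so the arrangement at this one carbon matters, but the S form keeps a clear effect on the enzyme.

As far as these compounds go, it remains open whether R would still give the lower number if the amine were replaced by a hydroxyl group or if the chain were longer. A single pair also cannot show whether the same flip would cost as much on a different core.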